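A few compounds are considered here, and "the series" means these few. Any claim that something is new, unique, unknown or untested is made for them only; others in the source may bear on it.

The measured compounds:

compound 1, `CNC(=O)c1cc(Oc2ccc(NC(=O)c3nccc(-c4cccc(Cl)c4)n3)cc2)ccn1`, gives > 100000 nM in a functional assay on A549 cells (Homo sapiens) for cytotoxicity, read by MTT assay, with a stated time of 72 h; on this read-out lower numbers stand for stronger inhibition and higher numbers for weaker inhibition
compound 2, `CNC(=O)c1cc(Oc2ccc(NC(=O)c3nccc(-c4ccc(C)cc4)n3)cc2F)ccn1`, gives 33200 nM in this assay

The entry for compound 1 in this assay is a limit of the assay rather than a number, as seen in the limit of > 100000 nM in this assay, at which 1 of the 2 values shown sits. Among the figures shown, compound 2 therefore holds the only real number in this assay, with 33200 nM. Going by the values given here, compound 2 and compound 1 also differ in more than one place, so their two values show only that compound 2 has a measurable number while compound 1 does not.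

The unmeasured compound 3, `CNC(=O)c1cc(Oc2ccc(NC(=O)c3nccc(-c4ccc(C)cc4)n3)cc2)ccn1`, differs from compound 2 by hydrogen in place of fluoro on an aromatic carbon. Among the compounds with values here, no step between two measured compounds that differ in one place is available, so the size of this change must be estimated from the structure alone. Removing a single fluoro is a small structural change, and the step of a 1.5-fold higher number from compound 2 to compound 3 (0.18 log units; within the scatter) is expected to be modest, toward weaker inhibition or nothing beyond the usual scatter. Compound 3 is expected to give about 50000 nM in this assay, most likely between 15000 nM and 150000 nM.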

Compound 3, half-maximal inhibitory concentration: 28400 nM
For compound 3 the middle estimate is 1.8-fold (0.25 log units) above the measured one, within the range that was stated.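

In this assay, the fluoro on the aromatic carbon ortho to a (2-(methylcarbamoyl)pyridin-4-yl)oxy group can give way to hydrogen with no change that stands out, the step being a 1.2-fold lower number from compound 2 to compound 3 (0.07 log units; within the scatter), so at this position the two compounds cannot be told apart. Compound 3 also opens a second comparison in one place, 4-methylphenyl in place of 3-chlorophenyl, which gives an at least 3.5-fold lower number from compound 1 to compound 3 (0.54 log units; beyond the scatter), and this step, unlike the fluoro step, lies beyond the scatter. The entry for compound 1 is a limit of the assay and not a number, so the true size of that step stays unknown: the limit of > 100000 nM in this assay, at which 1 of the 3 values shown sits.

Going by these compounds, whether a larger group on the same aromatic carbon, such as methoxy or an amine, would also leave the number within the scatter remains open. The aryl step also changes both the substituent and its place on the phenyl ring, and only a comparison with 4-chlorophenyl or 3-methylphenyl could show which of the two matters.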